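The compounds below may be only part of what the source reports. "The series", "measured", "known", "first", "only" and "open" are said of these compounds alone.

Of the compounds shown here, three sharing one core have been tested in an ADME assay on HEK-293T cells (Homo sapiens) for cytotoxicity, read by CCK-8 assay, with a stated time of 24 h; on this read-out lower numbers stand for higher toxicity in this test and higher numbers for lower toxicity in this test. Compound 1 `O=C(CSc1c[nH]c2c(Br)cccc12)N(Cc1ccccc1)Cc1ccccc1` returns a limit of the test rather than a number, > 100000 nM. Compound 2 `COc1ccccc1CNC(=O)CSc1c[nH]c2ccc(Br)cc12` likewise returns only a limit, > 100000 nM. Compound 3 `CN(Cc1ccccc1)C(=O)CSc1c[nH]c2c(Br)cccc12` gives a number, 52500 nM. Among the measured compounds shown here, the single measured step, an at least 1.9-fold lower number from compound 1 to compound 3 (0.27 log units; that floor lies within the scatter), rests on a limit at one end, so its size is known only as a floor. Compound 2 thus stands at the edge of what this assay reports, sharing the limit of > 100000 nM in this assay, at which 2 of the 3 values shown sit, with one other compound.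

The untested compound 4 `O=C(CSc1c[nH]c2ccc(Br)cc12)NCc1ccc(Cl)c(Cl)c1` differs from compound 2 in one place: 3,4-dichlorophenyl in place of 2-methoxyphenyl on a saturated chain carbon bound to an amide-type nitrogen. For the measured compounds named here, the only measured step alters the same kind of position by a different exchange, and its floor lies within the scatter, so it gives no ground for expecting movement. In this assay, compound 4 is therefore expected to show no step beyond the scatter, a number no higher from compound 2 to compound 4 (the limit leaves the size open), and most probably another limit. The estimate for compound 4 is 100000 nM, with a range from 30000 nM to 300000 nM.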

Compound 4, half-maximal cytotoxic concentration: > 100000 nM
Compound 4 ended at the assay's limit (the forecaster's own chance of this, stated with the estimate: 60%); the middle value lies on the limit itself.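

In this assay compound 4, like compound 2, returns a limit of the test rather than a number, so no step can be read between them: the limit of > 100000 nM in this assay, at which 3 of the 4 values shown sit.

The compounds shown leave open whether 3,4-dichlorophenyl and 2-methoxyphenyl on a saturated chain carbon bound to an amide-type nitrogen differ at all in this assay.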